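A Fluorocyclobutyl Swap at the Stability Limit

The source may hold more compounds than are shown below. What is called first, only, known or untested is meant among the compounds shown, and "the series" means these compounds.

Compound 1 `Nc1ncnc2c1c(Oc1cc(C(F)(F)F)ccn1)nn2C1CC1` reads > 2.41 h in an ADME assay on microsomes from liver (Homo sapiens) for metabolic stability, read by LC-MS, using NADPH, with a stated time of 10 min, tested at 10 uM (on this read-out lower numbers stand for a shorter-lived compound and higher numbers for a longer-lived compound), and that reading is a limit, not a number. Compound 2 `Nc1ncnc2c1c(Oc1cc(O)ccn1)nn2C1CCC(F)(F)CC1` reads > 2.41 h as a limit of the same kind. Compound 3 `N#Cc1ccnc(Oc2nn([C@H]3C[C@H](O)C3)c3ncnc(N)c23)c1` gives > 2.41 h and this too is a limit. Among the compounds with values here, the series so far comes down to the limit of > 2.41 h in this assay, at which 3 of the 3 values shown sit, and so none of the three can be ranked against another.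

Compound 4 `Nc1ncnc2c1c(Oc1cc(C(F)(F)F)ccn1)nn2[C@H]1C[C@H](F)C1` keeps the core of compound 1 and carries 3-fluorocyclobutyl in place of cyclopropyl on an aromatic nitrogen, a change counted as 3-fluorocyclobutyl in place of cyclopropyl on an aromatic nitrogen in full. Within the data shown here, no pair of measured compounds differs in one place alone, so no measured step sets the size of this change. The expectation rests on compound 3, which has a different non-aromatic ring on that nitrogen and still stands at its limit of > 2.41 h in this read-out. The estimated step in this assay is a step that the limit leaves unreadable from compound 1 to compound 4 and it is expected to stay within the usual scatter, with no clear direction. For compound 4 the estimate is 2.5 h with an expected range from 1.3 h to 5 h and the reading may well prove to be a limit again.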

Compound 4, half-life: 2.03 h
Compound 4: middle estimate off by 1.2-fold (0.09 log units), on the high side; low and high end bracket the measured number.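

In this assay, within the data shown here, compound 4 gives 2.03 h, the first reading that is a number and not a limit, so this position on the aromatic nitrogen now has a value that later changes can be read against. The change to 3-fluorocyclobutyl in place of cyclopropyl reads as an at least 1.1-fold lower number from compound 1 to compound 4 (0.07 log units; that floor lies within the scatter); only this floor is known, so the full size of the step cannot be read and it may be larger than the floor. The reading of compound 4 also stands alone in the series, since no other compound yet has a number to set beside it and the rest remain at a limit: the limit of > 2.41 h in this assay, at which 3 of the 4 values shown sit.

The compounds shown leave open whether the step belongs to the fluorine or to the larger ring, a question that an unsubstituted cyclobutyl on the same nitrogen, with the trifluoromethyl group kept, would separate. Also open, from the compounds shown here alone, is how the other stereoisomer of 3-fluorocyclobutyl would read on the core of compound 1, and whether a cyclopentyl there would give a number or return to the limit.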